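This account rests on a few compounds, and the source may have more. Where it says the series, first, only, none or still open, it means among the compounds named here.

Measured so far:
compound 1, `CCCCC(CC(=O)O[C@H](CC=C(C)C)C1=CC(=O)c2c(O)ccc(O)c2C1=O)OC(C)=O`: 67700 nM
compound 2, `CCC(O)CO[C@H](CC=C(C)C)C1=CC(=O)c2c(O)ccc(O)c2C1=O`: 16400 nM
compound 3, `CCCCCCC(C)(O)CC(=O)O[C@H](CC=C(C)C)C1=CC(=O)c2c(O)ccc(O)c2C1=O`: a limit of the assay, > 100000 nM

In a functional assay on DU-145 cells (Homo sapiens) for cytotoxicity, read by MTT assay (on this read-out lower numbers stand for stronger inhibition and higher numbers for weaker inhibition), compound 2 holds the lowest of the two numbers given, and the gap to compound 1 lies beyond the scatter. Compound 4, `CCC(CO[C@H](CC=C(C)C)C1=CC(=O)c2c(O)ccc(O)c2C1=O)OC`, differs from compound 2 by methyl in place of hydrogen on an oxygen on a saturated carbon. Among the measured compounds shown here, the only measured step, an at least 1.4-fold higher number from compound 1 to compound 3 (0.16 log units; that floor lies within the scatter), alters the ester chain and not the ether side, and compound 3 sits at the assay limit (the limit of > 100000 nM in this assay, at which 1 of the 3 values shown sits), so it says little about capping a hydroxy. For the measured compounds named here, with no step bearing directly on this change, no shift beyond the scatter is expected, a 1.0-fold lower number from compound 2 to compound 4 (0.01 log units; within the scatter). Compound 4 is therefore estimated at 16000 nM, between 6000 nM and 45000 nM.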

Compound 4, half-maximal inhibitory concentration: 45700 nM
The estimate for compound 4 lay 2.9-fold (0.46 log units) below the measured number, and the stated range ends below it.
By their numbers in this assay, from the lowest: compound 2; then compounds 4 and 1 (each within the scatter of the next). At a limit, above all of these: compound 3.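

In this assay, replacing hydroxy with methoxy is not neutral at this position: the change gives a 2.8-fold higher number from compound 2 to compound 4 (0.45 log units; beyond the scatter), a modest step, and the lower number goes with the free hydroxy. This is the first step shown on the ether side, as the earlier step altered only the ester chain. Nothing shown accounts for this shift. From the compounds shown here alone, whether an amine in place of the hydroxy, or an ethyl or acetyl group on this oxygen, would move the number remains open. So does whether the same change would have a similar effect on an ester-linked chain.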